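The source may hold more compounds than are shown below. What is called first, only, known or untested is meant among the compounds shown, and "the series" means these compounds.

Measured compounds:

Compound 1, `O=C(c1cc(-c2ccc(=O)[nH]c2)on1)N1CCC(Cc2ccccc2)CC1`: in an ADME assay on the whole organism (Rattus norvegicus, strain Sprague-Dawley) for pharmacokinetics, using cassette dosing, at a dose of 0.5 mg/kg by the intravenous route (on this read-out higher numbers stand for fast clearance and lower numbers for slow clearance), compound 1 gives 19.3 mL/min/kg.
Compound 2, `O=C(c1cc(-c2ccc(=O)[nH]c2)on1)N1CCC(Cc2ccc(F)cc2)CC1`: in this assay compound 2 gives 19.7 mL/min/kg.
Compound 3, `O=C(Nc1ccc2[nH]c(=O)oc2c1)C(=O)N1CCN(c2ccccc2)CC1`: in this assay compound 3 gives "not determined" (no result reported), so no result was reported for it.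

Compound 2 carries the change fluoro in place of hydrogen on an aromatic carbon relative to compound 1, and the step it made was a 1.0-fold higher number from compound 1 to compound 2 (0.01 log units; within the scatter), so the added fluorine left clearance essentially where it was. Compound 4, `O=C(Nc1ccc2[nH]c(=O)oc2c1)C(=O)N1CCN(c2ccc(F)cc2)CC1`, has not yet been measured; it stands to compound 3 as compound 2 stands to compound 1, carrying the change fluoro in place of hydrogen on an aromatic carbon at the same kind of place. The difference between the core of compound 1 and the core of compound 3 is not broken down here, and compound 3 itself has no number to anchor from. Among the measured compounds shown here, on the only precedent, the fluorine step from compound 1 to compound 2, a 1.0-fold higher number from compound 1 to compound 2 (0.01 log units; within the scatter), the expected step for compound 4 is small, but its absolute level can only be guessed broadly. Compound 4 is therefore expected to show about 20 mL/min/kg, somewhere between 6 mL/min/kg and 60 mL/min/kg.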

Compound 4, clearance: 11.1 mL/min/kg
Compound 4: the middle estimate sits 1.8-fold (0.26 log units) above what was measured, within the range that was stated.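

In this assay, among the compounds shown here, compound 3 gives "not determined" (no result reported), so no step to compound 4 can be read. The compounds shown leave open whether going from phenyl to 4-fluorophenyl changes clearance on the core of compound 3, as it barely did on the core of compound 1. No evidence here bears on the value of compound 4.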